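The source may report more compounds than this note shows. Statements on the series, on what has been measured and on what is new or still open speak of the compounds shown alone.

The series comprises three measured amides and one still to be tested. Compound 1 `CCCCCC[C@@H](O)C/C=C\CCCCCCCC(=O)N1CCOCC1` carries a morpholin-4-yl group on the carbonyl carbon of a hydroxylated unsaturated chain, and in a functional assay on NCI-H460 cells (Homo sapiens) for antiproliferative activity, read by sulforhodamine B assay, with a stated time of 48 h (on this read-out lower numbers stand for stronger inhibition of growth and higher numbers for weaker inhibition of growth), compound 1 gives 49.1 ug/mL. Within the data shown here, compound 2 `CCCCCC[C@@H](O)C/C=C\CCCCCCCC(=O)N[C@@H](C)c1ccccc1` keeps that chain and in this assay compound 2 gives 8.3 ug/mL; the change a 5.9-fold lower number from compound 1 to compound 2 (0.77 log units; beyond the scatter) is the only step so far that touches the group on the carbonyl carbon. Compound 3 `CCCCCCCCCCCCCCCCCC(=O)N1CCCC1` has a fully saturated chain with pyrrolidin-1-yl on the carbonyl carbon, and in this assay compound 3 gives 10.8 ug/mL. Among the three numbers compound 3 stands second highest: its value and that of compound 2 lie within the scatter of each other, while compound 1 lies beyond the scatter above it.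

Compound 4 `CCCCCCCCCCCCCCCCCC(=O)N1CCOCC1` differs from compound 3 by morpholin-4-yl in place of pyrrolidin-1-yl on a carbonyl carbon. Among the measured compounds shown here, no measured pair compares pyrrolidin-1-yl with morpholin-4-yl directly. For the measured compounds named here, the one step that bears on the group at this position, a 5.9-fold lower number from compound 1 to compound 2 (0.77 log units; beyond the scatter), shows the morpholin-4-yl compound with the highest number in the set. On that basis a modest rise in the number is expected for compound 4, a 2.3-fold higher number from compound 3 to compound 4 (0.36 log units; beyond the scatter), so that compound 4 is estimated at 25 ug/mL in this assay, with a plausible range from 10 ug/mL to 60 ug/mL.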

Compound 4, concentration for 50% growth inhibition: 53.1 ug/mL
Beside the measured number, compound 4's estimate is 2.1-fold (0.33 log units) below it; the range from low to high includes it.
By their numbers in this assay, from the lowest: compounds 2 and 3 (each within the scatter of the next); then compounds 1 and 4 (each within the scatter of the next).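

Among these compounds, the step of a 4.9-fold higher number from compound 3 to compound 4 (0.69 log units; beyond the scatter) in this assay is the first direct comparison of morpholin-4-yl with pyrrolidin-1-yl on a carbonyl carbon whose other neighbour is a saturated chain carbon. Among the compounds shown here, it shows that, with the saturated chain held fixed, this exchange at the carbonyl carbon alone moves the number beyond the scatter, whereas the earlier step at this position, a 5.9-fold lower number from compound 1 to compound 2 (0.77 log units; beyond the scatter), was seen only on the hydroxylated unsaturated chain and with a quite different group entering. The two morpholin-4-yl amides, compound 1 and compound 4, now hold the two highest numbers of the four, on two different chains, and no compound shown goes against this; nothing given here explains the change in the number.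

The compounds shown leave open whether the step follows the ring size or the ring oxygen, which piperidin-1-yl, a six-membered ring without that oxygen, would help to separate. They also leave open whether pyrrolidin-1-yl on the hydroxylated unsaturated chain, or (1-phenylethyl)amino on the saturated chain, would give numbers in line with those seen here.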